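The source may hold more compounds than are shown below. What is called first, only, known or untested is meant among the compounds shown, and "the series" means these compounds.

In a functional assay on Caco-2 cells (Homo sapiens) for inhibition, read by MTT assay, with a stated time of 48 h, tested at 10 uM (on this read-out higher numbers stand for more inhibition of growth at the one concentration tested and lower numbers for less inhibition of growth), three compounds built on a shared core have been measured, and their numbers all lie within the usual scatter of one another. Compound 1 `Cc1cc(=O)c2c(O)cc(OCc3ccc([N+](=O)[O-])cc3)c([C@H]3CCN(C)C[C@H]3O)c2o1` gives 14%, compound 2 `Cc1cc(=O)c2c(O)cc(OC/C=C/c3ccccc3)c([C@H]3CCN(C)C[C@H]3O)c2o1` gives 9%, and compound 3 `Cc1cc(=O)c2c(O)c(CN3CCCC3CO)c(O)c([C@H]3CCN(C)C[C@H]3O)c2o1` gives 19%. Compound 4 `Cc1cc(=O)c2c(O)c(CN3CCCC3C(=O)O)c(O)c([C@H]3CCN(C)C[C@H]3O)c2o1` differs from compound 3 in one place, with carboxy in place of hydroxymethyl on a saturated ring carbon. Going by the values given here, only one measured step exists, a number 5 percentage points lower from compound 1 to compound 2 (within the scatter), and it swaps other groups, so it bears on this change only loosely. Given that step, no change beyond the scatter is expected. The estimate for compound 4 is 14%, with an expected range from 3% to 27%. This estimate means an expected a number 5 percentage points lower from compound 3 to compound 4 (within the scatter).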

Compound 4, percent growth inhibition at one concentration: 30%
Estimate against measurement, compound 4: 16 percentage points below; the measured number lies above the stated range.
By their numbers in this assay, from the lowest: compounds 2, 1 and 3 (each within the scatter of the next); then compound 4.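

In this assay, carboxy in place of hydroxymethyl on the saturated ring carbon gives a number 11 percentage points higher from compound 3 to compound 4 (beyond the scatter) and is the only step shown that lies beyond the scatter. Going by these compounds alone, this ring position therefore responds to the group it carries, something the earlier compounds, all within the scatter of one another, could not show. Nothing measured here explains the step. Open, from the compounds shown here alone, is whether a methyl ester, an amide or an amine on this carbon would read like the carboxy or like the hydroxymethyl.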